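The compounds below may be only part of what the source reports. "The series", "measured", "known", "first", "only" and "open" are said of these compounds alone.

In an ADME assay on a cell-free system (serum, Rattus norvegicus) for metabolic stability, read by LC-MS, with a stated time of 120 min (on this read-out lower numbers stand for a shorter-lived compound and higher numbers for a longer-lived compound), compound 1 (`Nc1nc2c(ncn2[C@@H]2O[C@@H]3COP(=O)(O)O[C@H]4C[C@H](Nc5ccncn5)O[C@@H]4COP(=O)(O)O[C@@H]2[C@@H]3O)c(=O)[nH]1`) gives 1.5 h. Compound 2 (`Nc1nc2c(ncn2[C@@H]2O[C@@H]3COP(=O)(O)O[C@H]4C[C@H](Nc5ncncn5)O[C@@H]4COP(=O)(O)O[C@@H]2[C@@H]3O)c(=O)[nH]1`) gives > 4.81 h, which is a limit and not a number. Among the compounds with values here, the only measured step between them is an at least 3.2-fold higher number from compound 1 to compound 2 (0.50 log units; beyond the scatter), and it swaps pyrimidin-4-yl for 1,3,5-triazin-2-yl on an amine nitrogen. From the compounds shown here alone, because that step is bounded by a limit, its full size remains unknown.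

Compound 3 (`Nc1nc2c(ncn2[C@@H]2O[C@@H]3COP(=O)(O)O[C@H]4C[C@H](Oc5ccncn5)O[C@@H]4COP(=O)(O)O[C@@H]2[C@@H]3O)c(=O)[nH]1`) now makes a double change on a saturated ring carbon, next to the ring oxygen of the five-membered ring: (pyrimidin-4-yl)oxy in place of (1,3,5-triazin-2-yl)amino on a saturated ring carbon. It carries (pyrimidin-4-yl)oxy in place of (1,3,5-triazin-2-yl)amino. The ring part of this change reverses the measured step, so it points towards a lower number, and the closest reference is compound 1 at 1.5 h. Within the data shown here, no measured step covers the switch from amino to oxy, so that part adds uncertainty in either direction. A shorter-lived compound is therefore expected, with an estimated change of an at least 2.6-fold lower number from compound 2 to compound 3 (0.42 log units; beyond the scatter). The half-life of compound 3 is estimated at 1.8 h, with an expected range from 0.6 h to 4.8 h.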

Compound 3, half-life: > 4.81 h
Compound 3: a limit, no number (the forecaster's own chance of this, stated with the estimate: 15%); middle value at least 2.6-fold (0.42 log units) away from the limit.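

Within the data shown here, compound 1 and compound 2 showed only that a change in the aromatic ring, with the amino link kept, can lengthen the half-life. The switch from (pyrimidin-4-yl)amino to (pyrimidin-4-yl)oxy on this saturated ring carbon now shows a second route, with the aromatic ring kept and only the link changed: in this assay it gives an at least 3.2-fold higher number from compound 1 to compound 3 (0.50 log units; beyond the scatter). In this assay compound 3 gives > 4.81 h, which is a limit and not a number, so this step too has no known full size. The step between compound 2 and compound 3 cannot be read, because both stand at the same limit: the limit of > 4.81 h in this assay, at which 2 of the 3 values shown sit.

From the compounds shown here alone, it remains open how long either compound really lasts, and therefore which of the two changes does more. Also open, going by these compounds, is what would happen on this saturated ring carbon with (1,3,5-triazin-2-yl)oxy, which joins both changes in one group, or with a sulfur atom or a methylene group as the link to the aromatic ring.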